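The source may report more compounds than this note shows. Statements on the series, on what has been measured and on what is new or still open speak of the compounds shown alone.

Measured compounds and their values:

Compound 1 `COc1ccc(/C=C/C(=O)O)cc1OC(=O)c1nc(C)c(C)nc1C`: 8800 nM
Compound 2 `COc1cc(/C=C/C(=O)O)cc(OC)c1OC(=O)c1nc(C)c(C)nc1C`: 34700 nM
Compound 3 `CCOC(=O)/C=C/c1ccc(OC)c(OC(=O)c2nc(C)c(C)nc2C)c1`: 29900 nM

The three compounds were tested in a functional assay on EA.hy 926 cells (Homo sapiens) for cytotoxicity, read by MTT assay, with stated times of 24 h and 12 h; a lower number here means that less compound is needed, a higher number that more compound is needed for the effect. In this assay compound 1 gives 8800 nM. Compound 3 carries one change relative to compound 1, namely (ethyl in place of hydrogen on an oxygen next to a carbonyl group), and this change produced a 3.4-fold higher number from compound 1 to compound 3 (0.53 log units; beyond the scatter). Compound 2 differs from compound 1 on its core; the difference between the two cores is not broken down here. In this assay compound 2 gives 34700 nM, and compound 3 gives 29900 nM, two values that lie within the usual scatter of each other.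

Compound 4 `CCOC(=O)/C=C/c1cc(OC)c(OC(=O)c2nc(C)c(C)nc2C)c(OC)c1` has not yet been measured. It stands to compound 2 as compound 3 stands to compound 1: the difference is ethyl in place of hydrogen on an oxygen next to a carbonyl group, at the same place as before, so it is the same change, now made on the core of compound 2. Among the compounds shown this change appears twice in all, once measured and once not.

The expectation for compound 4 rests on a single precedent, the step of a 3.4-fold higher number from compound 1 to compound 3 (0.53 log units; beyond the scatter), transferred to another core. Whether the core of compound 2 responds in the same way is not known from these data, so the expected step is set a little smaller than the measured one and given a wide range. On this basis the step from compound 2 to compound 4 is expected to be a 2.4-fold higher number from compound 2 to compound 4 (0.39 log units; beyond the scatter). Compound 4 is therefore estimated at 85000 nM in this assay, with a range from 40000 nM to 180000 nM.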

Compound 4, half-maximal effective concentration: 21400 nM
Compound 4: middle estimate off by 4.0-fold (0.60 log units), on the high side, and the stated range ends above it.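

On the core of compound 2, ethyl in place of hydrogen on an oxygen next to a carbonyl group gave a 1.6-fold lower number from compound 2 to compound 4 (0.21 log units; within the scatter) in this assay, so no real shift can be claimed for the change on this core. Among these compounds, the step measured on the core of compound 1 therefore did not carry over to the core of compound 2, and the outcome of this change differed between the two cores: the same change on two cores in this assay, a 3.4-fold higher number (0.53 log units; beyond the scatter) from compound 1 to compound 3 and a 1.6-fold lower number (0.21 log units; within the scatter) from compound 2 to compound 4, 5.5-fold (0.74 log units) apart, beyond the scatter of two such steps This rests on only two pairs of compounds, so it shows that the step cannot be assumed to transfer here, but it does not show which feature of the two cores lies behind the difference or how the change would behave on any further core.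

The compounds shown leave open whether a different group at this place, such as methyl, a longer chain on the same oxygen, or an amide in place of ethoxycarbonyl, would follow the pattern of the core of compound 1 or that of the core of compound 2. They also leave open whether the same difference between the two cores would appear in any other assay.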